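This account rests on a few compounds, and the source may have more. Where it says the series, first, only, none or still open, it means among the compounds named here.

In a functional assay for inhibition of sodium/hydrogen exchanger (Oryctolagus cuniculus) (on this read-out higher numbers stand for weaker inhibition and lower numbers for stronger inhibition), the measured compounds give:
compound 1, `CS(=O)(=O)c1cc(C(=O)N=C(N)N)c(Cl)cc1Cl`: 140 nM
compound 2, `CS(=O)(=O)c1cc(C(=O)N=C(N)N)c(Cl)cc1Oc1cccnc1`: 52 nM
compound 3, `CS(=O)(=O)c1cc(C(=O)N=C(N)N)c(Cl)cc1-n1ccnc1`: 130 nM

Compound 3 stands second highest of the three numbers and within the scatter of compound 1; the only gap beyond the scatter is a 2.5-fold higher number from compound 2 to compound 3 (0.40 log units; beyond the scatter). Compound 4, `CS(=O)(=O)c1cc(C(=O)N=C(N)N)c(Cl)cc1Nc1ncccn1`, differs from compound 3 by (pyrimidin-2-yl)amino in place of 1H-imidazol-1-yl on an aromatic carbon. Going by the values given here, two measured steps bear on this: a 1.1-fold lower number from compound 1 to compound 3 (0.03 log units; within the scatter), which left the number unchanged, and a 2.7-fold lower number from compound 1 to compound 2 (0.43 log units; beyond the scatter), where (pyridin-3-yl)oxy, also built on a six-membered aromatic ring, brought a modestly lower number. Because of a 2.7-fold lower number from compound 1 to compound 2 (0.43 log units; beyond the scatter), a modest downward step is expected, a 1.9-fold lower number from compound 3 to compound 4 (0.27 log units; within the scatter) in this assay. The estimate for compound 4 is 70 nM, within 30 nM to 160 nM.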

Compound 4, half-maximal inhibitory concentration: 49 nM
Beside the measured number, compound 4's estimate is 1.4-fold (0.15 log units) above it; low and high end bracket the measured number.
By their numbers in this assay, from the lowest: compounds 4 and 2 (each within the scatter of the next); then compounds 3 and 1 (each within the scatter of the next).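

In this assay, (pyrimidin-2-yl)amino on this aromatic carbon, ortho to the methylsulfonyl group, gives a real drop where 1H-imidazol-1-yl gave none (see a 2.7-fold lower number from compound 3 to compound 4 (0.42 log units; beyond the scatter) and a 2.9-fold lower number from compound 1 to compound 4 (0.46 log units; beyond the scatter)). It also stands level with (pyridin-3-yl)oxy (a 1.1-fold lower number from compound 2 to compound 4 (0.03 log units; within the scatter)), so a second group carrying a six-membered aromatic ring, attached through an amino link instead of an oxy link, gives a lower number than chloro. Among these four compounds, only the two groups with six-membered rings do so.

From the compounds shown here alone, whether a plain amine or a phenylamino group here would give the same lower number stays open. No measurement shown explains these steps.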